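This account rests on a few compounds, and the source may have more. Where it says the series, first, only, none or still open, it means among the compounds named here.

Measured so far in a functional assay on T47D cells (Homo sapiens) for inhibition; on this read-out higher numbers stand for weaker inhibition and lower numbers for stronger inhibition:

Compound 1, `Oc1ccccc1-c1cc(-c2cccc(C(F)(F)F)c2)cc(-c2ccccc2O)n1`, gives only the assay limit > 50000 nM.
Compound 2, `Oc1ccccc1-c1cc(-c2ccc(C(F)(F)F)cc2)cc(-c2ccccc2O)n1`, likewise gives only the limit > 50000 nM.
Compound 3, `Oc1cccc(-c2cc(-c3cccc(C(F)(F)F)c3)cc(-c3cccc(O)c3)n2)c1`, gives 4970 nM.

Compound 4, `Oc1cccc(-c2cc(-c3ccc(C(F)(F)F)cc3)cc(-c3cccc(O)c3)n2)c1`, awaits measurement in this assay. The change 4-(trifluoromethyl)phenyl in place of 3-(trifluoromethyl)phenyl on an aromatic carbon produced a step that the two limits leave unreadable from compound 1 to compound 2, unreadable because the limit of > 50000 nM in this assay, at which 2 of the 3 values shown sit, holds both values. Compound 4 carries the same kind of change, (4-(trifluoromethyl)phenyl in place of 3-(trifluoromethyl)phenyl on an aromatic carbon); the place differs, the entering group standing meta to two 3-hydroxyphenyl groups rather than meta to two 2-hydroxyphenyl groups. How the core of compound 3 differs from the core of compound 1 is not broken down here. With no readable precedent, the step is expected to be about a 1.0-fold higher number from compound 3 to compound 4 (0.00 log units; within the scatter), resting only on compound 3 at 4970 nM as the starting point. Compound 4 is therefore estimated at 5000 nM, between 1500 nM and 20000 nM.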

Compound 4, half-maximal inhibitory concentration: 2330 nM
Compound 4: middle estimate off by 2.1-fold (0.33 log units), on the high side; the measured number falls inside the stated range.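

In this assay, 4-(trifluoromethyl)phenyl in place of 3-(trifluoromethyl)phenyl on the core with two 3-hydroxyphenyl groups gives a 2.1-fold lower number from compound 3 to compound 4 (0.33 log units; beyond the scatter). The same change on the core with two 2-hydroxyphenyl groups cannot be read, because compound 1 and compound 2 both give only a limit and no number: the limit of > 50000 nM in this assay, at which 2 of the 4 values shown sit. The step is therefore readable on one core only, and nothing shown tells whether it carries over to another core.

The compounds shown leave open how the read-out responds to an amine or a carboxylic acid in place of the trifluoromethyl group. Also open, as far as these compounds go, is how it moves with a methoxy group in place of each hydroxyl.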